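One Ring Swap, Measured Once, Expected Again

The compounds below may be only part of what the source reports. "The series", "measured", "known", "first", "only" and "open" are said of these compounds alone.

Compound 2 `O=C1O/C(=C\Cn2c(=O)[nH]c(=O)[nH]c2=O)C(OCc2ccccc2)=C1OCc1ccccc1` and compound 1 `Nc1ncn(C/C=C2\OC(=O)C(OCc3ccccc3)=C2OCc2ccccc2)c(=O)n1` differ in one place: a group of 8 heavy atoms (3 carbon, 4 nitrogen, 1 oxygen; one six-membered aromatic ring with 3 hetero atoms) in place of a group of 9 heavy atoms (3 carbon, 3 nitrogen, 3 oxygen; one six-membered aromatic ring with 3 hetero atoms), on a saturated chain carbon bound to a double-bonded chain carbon. In an ADME assay on WI-38 cells (Homo sapiens) for inhibition, read by MTT assay, with a stated time of 72 h (a lower number here means a stronger inhibitor, a higher number a weaker inhibitor), compound 2 gives 10 nM, while compound 1 gives 4670 nM. That single exchange produced a 470-fold higher number from compound 2 to compound 1 (2.67 log units; beyond the scatter).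

Compound 3 `O=C1O[C@H]([C@@H](O)Cn2c(=O)[nH]c(=O)[nH]c2=O)C(OCc2ccccc2)=C1OCc1ccccc1` carries a different core; how it differs from compound 2 is not broken down here. In this assay compound 3 returns > 100000 nM, which is a limit of the assay rather than a number. It sits at the limit of > 100000 nM in this assay, at which 1 of the 3 values shown sits.

Compound 4 `Nc1ncn(C[C@H](O)[C@H]2OC(=O)C(OCc3ccccc3)=C2OCc2ccccc2)c(=O)n1` stands to compound 3 as compound 1 stands to compound 2: a group of 8 heavy atoms (3 carbon, 4 nitrogen, 1 oxygen; one six-membered aromatic ring with 3 hetero atoms) in place of a group of 9 heavy atoms (3 carbon, 3 nitrogen, 3 oxygen; one six-membered aromatic ring with 3 hetero atoms), on a saturated chain carbon, two bonds along the chain from an oxygen on a saturated carbon and a saturated ring carbon. The place is not word for word the same, since in compound 2 the group sits on a saturated chain carbon bound to a double-bonded chain carbon, whereas in compound 3 it sits on a saturated chain carbon, two bonds along the chain from an oxygen on a saturated carbon and a saturated ring carbon, so this is the same kind of change rather than the same one.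

Compound 4 is therefore expected near 500000 nM, within 100000 nM to 3000000 nM, most likely reported again as a limit. The expected step is a step that the limit leaves unreadable from compound 3 to compound 4, resting on the weakening recorded as a 470-fold higher number from compound 2 to compound 1 (2.67 log units; beyond the scatter) and on the limit recorded for compound 3.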

Compound 4, half-maximal inhibitory concentration: > 100000 nM
Compound 4: a limit, no number; the forecaster's own chance of this, stated with the estimate: 90%; the middle value does not contradict the limit.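

In this assay compound 4 returns > 100000 nM, which is a limit of the assay and not a number. With compound 3 also at a limit, no step can be read between compound 3 and compound 4: the limit of > 100000 nM in this assay, at which 2 of the 4 values shown sit.

The compounds shown leave open how large the exchange seen between compound 2 and compound 1 is on the core of compound 3.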